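A few compounds are considered here, and "the series" means these few. Any claim that something is new, unique, unknown or untested is made for them only; others in the source may bear on it.

Three compounds share one core and differ only in the group attached to the six-membered aromatic ring with one nitrogen. Compound 1 `Cc1ccc(Cl)cc1Nc1nc(C(F)(F)F)ccc1CNC(=O)C(C)c1ccc(NS(C)(=O)=O)c(F)c1` gives 14 nM in a functional assay on CHO-K1 cells for antagonist activity at transient receptor potential cation channel subfamily V member 1 (Homo sapiens), read by FLIPR; on this read-out lower numbers stand for stronger inhibition and higher numbers for weaker inhibition. Compound 2 `CC(C(=O)NCc1ccc(C(F)(F)F)nc1NCc1ccc(Cl)cc1)c1ccc(NS(C)(=O)=O)c(F)c1` gives 65.7 nM, a change of a 4.7-fold higher number from compound 1 to compound 2 (0.67 log units; beyond the scatter). Compound 3 `CCCN(CCC)c1nc(C(F)(F)F)ccc1CNC(=O)C(C)c1ccc(NS(C)(=O)=O)c(F)c1` gives 0.2 nM, the lowest of the three numbers and therefore the strongest inhibitor here; the steps to it are a 70-fold lower number from compound 1 to compound 3 (1.85 log units; beyond the scatter) and a 330-fold lower number from compound 2 to compound 3 (2.52 log units; beyond the scatter), both large and both beyond the scatter.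

Compound 4 `CCCCN(C)c1nc(C(F)(F)F)ccc1CNC(=O)C(C)c1ccc(NS(C)(=O)=O)c(F)c1` is not yet measured. It differs from compound 3 by butyl(methyl)amino in place of dipropylamino on an aromatic carbon. Both of the large measured steps replaced an amino group carrying an aromatic ring with one carrying two plain chains, and both ended at compound 3. For the measured compounds named here, the change to compound 4 keeps two plain chains on the nitrogen and only shifts one carbon from one chain to the other, so neither measured step speaks directly to it; the data hold no step between two dialkylamino compounds. The expectation is therefore a step of a 2.0-fold higher number from compound 3 to compound 4 (0.30 log units; within the scatter), that is, no change beyond the scatter or at most a small loss. Compound 4 is expected to give about 0.4 nM, within a range from 0.1 nM to 1.5 nM.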

Compound 4, inhibition constant: 0.8 nM
The estimate for compound 4 lay 2.0-fold (0.30 log units) below the measured number; low and high end bracket the measured number.
By their numbers in this assay, from the lowest: compound 3; then compound 4; then compound 1; then compound 2.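

Going from dipropylamino (6 carbon) to butyl(methyl)amino (5 carbon) is the first change here between two amino groups that both carry only plain chains, and it gives a 4.0-fold higher number from compound 3 to compound 4 (0.60 log units; beyond the scatter) in this assay, so this position still responds when no aromatic ring is involved, though far less than when one is removed. Compound 4 also keeps a wide lead over the compounds with a ring on the amino group, with an 82-fold lower number from compound 2 to compound 4 (1.91 log units; beyond the scatter) and an 18-fold lower number from compound 1 to compound 4 (1.24 log units; beyond the scatter), so the advantage of two plain chains now appears in a second compound, not only in compound 3. No measurement shown here explains the size of any of these steps.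

This change both removes a carbon and makes the two chains unequal, so the two effects cannot be separated, and butyl(ethyl)amino, which has the same carbon count as dipropylamino but unequal chains, would address that point. As far as these compounds go, it also remains open how shorter or longer pairs of chains, such as diethylamino or dibutylamino, would compare with dipropylamino at this position.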